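Esters of a shared core: methyl to nitro

A few compounds are considered here, and "the series" means these few. Any claim that something is new, unique, unknown or untested is made for them only; others in the source may bear on it.

Measured so far:
compound 1 `CC1=CC[C@H](C(C)C)c2cc(C)c(OC(=O)c3cccc(C)c3)cc21` — 16.8%
compound 2 `Cc1cc2c(C(C)C)ccc(C)c2cc1OC(=O)c1ccc(C(F)(F)F)cc1` — 16.5%
compound 3 `CC1=CC[C@H](C(C)C)c2cc(C)c(OC(=O)c3ccc(C(F)(F)F)cc3)cc21` — 14.7%

All three were run in a functional assay on U-251 cells (Homo sapiens) for antiproliferative activity, read by sulforhodamine B assay, with a stated time of 48 h, tested at 50 uM; on this read-out higher numbers stand for more inhibition at the one concentration tested (going by the name of the read-out) and lower numbers for less inhibition. Compound 1 gives 16.8% there; compound 2 and compound 3 give numbers close to it, and the separations between any two of the three lie within the usual scatter of repeated measurements, so none of them can be set apart from the others on these numbers. Compound 1 thus sits in the same band as the rest of the set, with the whole series showing modest inhibition at the single concentration tested. Going by the values given here, no step between any two of the measured compounds is recorded.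

The next compound, compound 4 `CC1=CC[C@H](C(C)C)c2cc(C)c(OC(=O)c3cccc([N+](=O)[O-])c3)cc21`, differs from compound 1 in one place: nitro in place of methyl on an aromatic carbon. The change sits on an aromatic carbon of a six-membered aromatic ring of carbon only, on the ester-bearing aryl group, and the core is unchanged.

Among the compounds with values here, the measured set offers no step involving a nitro group, and the three aryl variations seen so far all land in the same band. The step from compound 1 to compound 4 in this assay is therefore expected to be small, without clear direction, and within the scatter: a number 1.2 percentage points higher from compound 1 to compound 4 (within the scatter). Compound 4 is expected to give about 18% in this assay, with a range from 7% to 30%.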

Compound 4, a percentage reported as inhibition, at one concentration (the size of the read-out at that concentration, not a potency): 44%
Compound 4: middle estimate off by 26 percentage points, on the low side; measured number outside the range, above it.
By their numbers in this assay, from the lowest: compounds 3, 2 and 1 (each within the scatter of the next); then compound 4.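

In this assay, going by these compounds alone, the change from 3-methylphenyl to 3-nitrophenyl gives a number 27.2 percentage points higher from compound 1 to compound 4 (beyond the scatter), and this is the first step that can be read at all. Within the data shown here, it shows that the aryl group of the ester, on the shared core, is not a silent position: a single replacement on an aromatic carbon, meta to a large group, moves the read-out out of the band held by the earlier compounds, which offered no one-place step and so could not show this. Nothing on hand speaks to what lies behind the step, which for now stands as one pair of compounds at one concentration.

Open, going by these compounds, is whether the step belongs to the nitro group itself or would also appear with another replacement at the same place, such as an amine, a nitrile or a carboxylic acid. Also open, on these data alone, is whether a nitro group elsewhere on the aryl ring, or on the core of compound 2, would behave the same way, and how the inhibition of compound 4 changes with concentration.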